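The source may hold more compounds than are shown below. What is called first, only, known or untested is meant among the compounds shown, and "the series" means these compounds.

Values so far in a physicochemical assay for lipophilicity, read by HPLC, in phosphate buffer, measured as octanol-water partition, with a stated time of 6 h, at pH 7.4; a lower number here means a more polar compound, a higher number a more lipophilic compound:

Compound 1 `O=C(Nc1ccccc1)Nc1cccc(Nc2nccc(Nc3ccc4[nH]ccc4c3)n2)c1` - >= 4 (a limit)
Compound 2 `O=C(Nc1ccccc1)Nc1cccc(Nc2nccc(Nc3ccc4cc[nH]c4c3)n2)c1` - >= 4 (a limit)

Compound 2 has no number in this assay and stands only at a limit (>= 4). Compound 1 is also reported only as a limit (>= 4). Going by the values given here, the single measured step, a step that the two limits leave unreadable from compound 1 to compound 2, therefore offers no size to carry forward, and the evidence amounts to the limit of >= 4 in this assay, at which 2 of the 2 values shown sit.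

Compound 3 `Cn1cc2ccc(Nc3ccnc(Nc4cccc(NC(=O)Nc5ccccc5)c4)n3)cc2n1` has 2-methyl-2H-indazol-6-yl in place of 1H-indol-6-yl on a nitrogen on an aromatic ring, and the change is counted as 2-methyl-2H-indazol-6-yl in place of 1H-indol-6-yl on a nitrogen on an aromatic ring. Among the compounds with values here, no measured step covers this exchange. The expectation starts from the limit of compound 2 (>= 4) and allows a modest downward move, though no measured size supports it. The expected step, a number at least 0.20 log units lower from compound 2 to compound 3 (that floor lies within the scatter), is a small, tentative estimate, and compound 3 may also be reported only as a limit. For compound 3 the estimated value is 3.8 (expected range 3.2 to 4.3).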

Compound 3, distribution coefficient: >= 4
Compound 3 was reported as a limit (the forecaster's own chance of this, stated with the estimate: 40%); middle value at least 0.20 log units away from the limit.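

In this assay compound 3 gives >= 4, which is a limit. The steps to compound 3 from compound 1 and from compound 2 therefore cannot be read. The compounds shown leave open whether exchanging 1H-indol-5-yl, 1H-indol-6-yl and 2-methyl-2H-indazol-6-yl changes the read-out at all, and the evidence stays: the limit of >= 4 in this assay, at which 3 of the 3 values shown sit.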